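Hexokinase series: amide-bearing linker in place of plain chain

The source may report more compounds than this note shows. Statements on the series, on what has been measured and on what is new or still open speak of the compounds shown alone.

Three iodoacetamide-tipped nucleotides have been measured in an assay on isolated protein for inhibition of hexokinase-1 (Rattus norvegicus), with a stated time of 6 h, tested at 10 mM; a lower number here means less inhibition, a higher number more inhibition at the concentration tested (going by the name of the read-out). Compound 1 `O=C(CI)NCCCCCC(=O)NCCCCCCNc1ncnc2c1ncn2[C@@H]1O[C@H](COP(=O)(O)OP(=O)(O)OP(=O)(O)O)[C@@H](O)[C@H]1O` gives 0%, and compound 2 `Nc1ncnc2c1nc(NCCCCCCCCNC(=O)CI)n2[C@@H]1O[C@H](COP(=O)(O)OP(=O)(O)OP(=O)(O)O)[C@@H](O)[C@H]1O` gives 0%. Compound 3 `O=C(CI)NCCCCCCCCNc1ncnc2c1ncn2[C@@H]1O[C@H](COP(=O)(O)OP(=O)(O)OP(=O)(O)O)[C@@H](O)[C@H]1O` gives 35%, the highest of the three numbers; its gap to compound 1 and to compound 2 is the same and lies beyond the scatter, so the inhibition in this assay is higher for compound 3 than for either other measured compound.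

Compound 4 `O=C(CI)NCCCCC(=O)NCCCCCCNc1ncnc2c1ncn2[C@@H]1O[C@H](COP(=O)(O)OP(=O)(O)OP(=O)(O)O)[C@@H](O)[C@H]1O` is not yet measured. It departs from compound 3 by a group of 12 heavy atoms (7 carbon, 2 nitrogen, 2 oxygen, 1 iodine; no ring) in place of a group of 7 heavy atoms (4 carbon, 1 nitrogen, 1 oxygen, 1 iodine; no ring), on a saturated chain carbon, six bonds along the chain from a nitrogen on an aromatic ring. For the measured compounds named here, no step of this kind has been measured directly. The closest relative in chain make-up among the measured compounds is compound 1, which carries an entering group of the same type and gives 0%. A downward step is therefore expected, beyond the scatter, from compound 3 to compound 4, a number 30 percentage points lower from compound 3 to compound 4 (beyond the scatter). For compound 4 the expected value in this assay is 5%, with a range from 0% to 20%.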

Compound 4, a percentage reported as inhibition, at one concentration (the size of the read-out at that concentration, not a potency): 0%
Compound 4: middle estimate off by 5 percentage points, on the high side; the range from low to high includes it.
By their numbers in this assay, from the lowest: compounds 1, 2 and 4 (each within the scatter of the next); then compound 3.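

In this assay, replacing the 2-(((iodomethyl)carbonyl)amino)ethyl group with the larger amide-bearing group, on the saturated chain carbon six bonds along the chain from a nitrogen on an aromatic ring, gives a number 35 percentage points lower from compound 3 to compound 4 (beyond the scatter). For the compounds shown here, this is the first direct step at this position. Within the amide-bearing linkers, ((iodomethyl)carbonyl)amino in place of (((iodomethyl)carbonyl)amino)methyl, on a saturated chain carbon four bonds along the chain from a carbonyl carbon, gives no change at the digits printed from compound 1 to compound 4 (within the scatter), so the two linkers cannot be told apart in this assay.

Nothing available bears on why the read-out falls with this change. Still open, on these data alone, is whether a longer chain carrying the same amide, or an ether oxygen in place of the amide, would bring inhibition back in this assay.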